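The source may hold more compounds than are shown below. What is called first, only, known or untested is meant among the compounds shown, and "the series" means these compounds.

Compound 3 `CCCCC(C)(O)CC(=O)O[C@H](CC=C(C)C)C1=CC(=O)c2c(O)ccc(O)c2C1=O` gives 60600 nM in a functional assay on HeLa cells (Homo sapiens) for cytotoxicity, read by MTT assay (on this read-out higher numbers stand for weaker inhibition and lower numbers for stronger inhibition), the highest of the three numbers recorded so far. Compound 2 `CCCC(O)CC(=O)O[C@H](CC=C(C)C)C1=CC(=O)c2c(O)ccc(O)c2C1=O` gives 59300 nM, and the step of a 1.0-fold higher number from compound 2 to compound 3 (0.01 log units; within the scatter) lies within the scatter, so these two cannot be told apart. Compound 1 `CC[C@@](C)(O)CC(=O)O[C@H](CC=C(C)C)C1=CC(=O)c2c(O)ccc(O)c2C1=O` gives 17900 nM, and the steps of a 3.3-fold higher number from compound 1 to compound 2 (0.52 log units; beyond the scatter) and a 3.4-fold higher number from compound 1 to compound 3 (0.53 log units; beyond the scatter) are both modest but beyond the scatter.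

Compound 4 `CC(C)=CC[C@@H](OCCO)C1=CC(=O)c2c(O)ccc(O)c2C1=O` is the next compound. Its change from compound 3 is 2-hydroxyethyl in place of (2-hydroxy-2-methylhexyl)carbonyl on an oxygen on a saturated carbon. The (2-hydroxy-2-methylhexyl)carbonyl group leaves the oxygen on the saturated carbon and 2-hydroxyethyl enters in its place. Among the measured compounds shown here, none of the measured steps removes this group; each of them only exchanges one hydroxy-bearing chain for another on the saturated chain carbon bound to the carbonyl carbon, and those exchanges moved the numbers modestly at most. For the measured compounds named here, there is thus no measured step that directly mirrors the present change, and the expectation rests on the observation that variation in this part of compound 3 has so far mattered little. Compound 4 is therefore expected to give 40000 nM, with a range from 10000 nM to 160000 nM. This expected result corresponds to a step of a 1.5-fold lower number from compound 3 to compound 4 (0.18 log units; within the scatter), wide in its uncertainty.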

Compound 4, half-maximal inhibitory concentration: 18600 nM
The estimate for compound 4 lay 2.2-fold (0.33 log units) above the measured number, and the stated range covers the measured number.
By their numbers in this assay, from the lowest: compounds 1 and 4 (each within the scatter of the next); then compounds 2 and 3 (each within the scatter of the next).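

In this assay the whole acyl group on the oxygen on a saturated carbon can leave without any loss against the three earlier compounds, which only exchanged one hydroxy-bearing chain for another: the record gives a 3.3-fold lower number from compound 3 to compound 4 (0.51 log units; beyond the scatter) and a 3.2-fold lower number from compound 2 to compound 4 (0.50 log units; beyond the scatter) as modest steps beyond the scatter, while a 1.0-fold higher number from compound 1 to compound 4 (0.02 log units; within the scatter) stays within it. The outcome therefore depends on which group is taken away, and a 2-hydroxyethyl of 3 heavy atoms matches the (2-hydroxy-2-methylbutyl)carbonyl of compound 1 while giving stronger inhibition than the (2-hydroxypentyl)carbonyl of compound 2 and the (2-hydroxy-2-methylhexyl)carbonyl of compound 3. Nothing available explains why these groups differ in this way.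

The compounds shown leave open whether the hydroxy group of the 2-hydroxyethyl contributes at all, which a plain ethyl ether or the free alcohol on that carbon would test. They also leave open how a longer chain such as 3-hydroxypropyl, or an amine such as 2-aminoethyl, would behave on the same oxygen.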